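Halogen swap on the aryl ring: chloro replaced by fluoro

The source may hold more compounds than are shown below. What is called first, only, known or untested is meant among the compounds shown, and "the series" means these compounds.

Compound 1 `O=C(N/N=C/c1ccc(Cl)cc1)c1cccnc1` is the chloro member of this small set of aryl hydrazones of the same core. In an ADME assay on HeLa cells (Homo sapiens) for cytotoxicity, read by microscopy (a lower number here means that less compound is tolerated, a higher number that more compound is tolerated), compound 1 gives only a limit of the assay, > 100 ug/mL. Compound 2 `O=C(N/N=C/c1cccc(Br)c1)c1cccnc1` carries bromo instead; in this assay compound 2 also gives only a limit, >= 100 ug/mL. Compound 1 therefore stands at the limit of > 100 ug/mL in this assay, at which 1 of the 2 values shown sits. Compound 2 stands at the limit of >= 100 ug/mL in this assay, at which 1 of the 2 values shown sits. Within the data shown here, with both values sitting at a limit, nothing can be said about any order between them, and no measured step exists in this set.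

Compound 3 `O=C(N/N=C/c1ccc(F)cc1)c1cccnc1` differs from compound 1 by fluoro in place of chloro on an aromatic carbon. Among the measured compounds shown here, since the two halogen members measured so far both reach the limit in this assay, the step from compound 1 to compound 3 is expected to be none beyond the usual scatter, most likely again ending at a limit. Compound 3 is thus estimated at 150 ug/mL, within a range of 70 ug/mL to 300 ug/mL. The expected step is a step that the limit leaves unreadable from compound 1 to compound 3, read as no real change.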

Compound 3, minimum cytotoxic concentration: > 100 ug/mL
Compound 3 was reported as a limit; the forecaster's own chance of this, stated with the estimate: 80%; the middle value is on the limit's open side.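

In this assay compound 3 gives > 100 ug/mL, which is a limit of the assay. Compound 1 is also reported only as a limit, so no step can be read between compound 1 and compound 3. The compounds shown leave open at what concentration any of them becomes cytotoxic, and whether the halogen matters at all.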